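Working notes on the step to compound 4

The source may report more compounds than this note shows. Statements on the series, on what has been measured and on what is new or still open speak of the compounds shown alone.

Values in an ADME assay on HEK-293T cells (Homo sapiens) for cytotoxicity, read by CCK-8 assay, with a stated time of 48 h; on this read-out higher numbers stand for weaker inhibition and lower numbers for stronger inhibition:
- compound 1 `O=S(=O)(NCCNC(=S)Nc1cccc(Cl)c1)c1ccc(-c2ccccc2OCc2ccccc2)s1` gives 10200 nM
- compound 2 `COc1cccc(NC(=S)NCCNS(=O)(=O)c2ccc(-c3ccccc3Oc3ccc([N+](=O)[O-])cc3)s2)c1` gives > 20000 nM, a limit
- compound 3 `COc1ccc(NC(=O)NCCNS(=O)(=O)c2ccc(-c3ccccc3Oc3ccc([N+](=O)[O-])cc3)s2)cc1` gives > 20000 nM, a limit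

Compound 3 has no number, only (the limit of > 20000 nM in this assay, at which 2 of the 3 values shown sit). Compound 4 `O=[N+]([O-])c1ccc(Oc2ccccc2-c2ccc(S(=O)(=O)NCCNC(=S)Nc3cccc(Cl)c3)s2)cc1` departs from compound 3 by one change: a group of 10 heavy atoms (7 carbon, 1 nitrogen, 1 sulfur, 1 chlorine; one six-membered aromatic ring of carbon only) in place of a group of 11 heavy atoms (8 carbon, 1 nitrogen, 2 oxygen; one six-membered aromatic ring of carbon only), on an amine nitrogen. For the measured compounds named here, the only measured step that bears on it is a step that the two limits leave unreadable from compound 2 to compound 3, so no size carries over. Compound 1 holds the entering group on its own core and gives 10200 nM, so compound 4 is expected to read lower than compound 3 in this assay. The expected step is an at least 1.3-fold lower number from compound 3 to compound 4 (0.12 log units; that floor lies within the scatter). For compound 4 the estimate is 15000 nM, with an expected range of 7000 nM to 30000 nM.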

Compound 4, half-maximal inhibitory concentration: 4990 nM
Compound 4: the middle estimate sits 3.0-fold (0.48 log units) above what was measured; measured number below the stated range.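

In this assay the amine nitrogen now shows a readable step, an at least 4.0-fold lower number from compound 3 to compound 4 (0.60 log units; beyond the scatter), and chloro in place of methoxy on an aromatic carbon gives an at least 4.0-fold lower number from compound 2 to compound 4 (0.60 log units; beyond the scatter). With that chloro group held constant, 4-nitrophenyl in place of benzyl on the oxygen gives a 2.0-fold lower number from compound 1 to compound 4 (0.31 log units; beyond the scatter), so the oxygen substituent also moves this read-out. Compound 2 and compound 3 each carry a limit rather than a number, so the first two steps are floors only: the limit of > 20000 nM in this assay, at which 2 of the 4 values shown sit.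

From the compounds shown here alone, the full size of those two steps stays open. Also open, going by these compounds, is what a fluoro or an amine in place of the chloro would give on the core of compound 4.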